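Swapping an aroyl group for acetyl at a urotensin receptor

A few compounds are considered here, and "the series" means these few. Any claim that something is new, unique, unknown or untested is made for them only; others in the source may bear on it.

Compound 1 `Cc1ccc(C(=O)N[C@H]2CCN(Cc3ccc(OCCCN(C)C)cc3)C2)cc1C` gives < 10000 nM in an assay on HEK293 cells for binding affinity to Urotensin-2 receptor (Homo sapiens), read by radioligand binding; on this read-out lower numbers stand for stronger inhibition and higher numbers for weaker inhibition; this is a limit, not a number.
Compound 2 `CN(C)CCCOc1ccc(CN2CC[C@H](NC(=O)c3ccc(C(F)(F)F)cc3)C2)cc1` gives < 10000 nM in this assay, again only a limit.
Compound 3 `CN(C)CCCOc1ccc(CN2CC[C@H](NC(=O)c3cccs3)C2)cc1` gives < 10000 nM in this assay, also a limit.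

Compound 3 therefore has no exact position: all three compounds sit at the limit of < 10000 nM in this assay, at which 3 of the 3 values shown sit, so the steps a step that the two limits leave unreadable from compound 1 to compound 3 and a step that the two limits leave unreadable from compound 2 to compound 3 cannot be read.

Compound 4 `CC(=O)N[C@H]1CCN(Cc2ccc(OCCCN(C)C)cc2)C1` differs from compound 3 by methyl in place of thiophen-2-yl on a carbonyl carbon. Among the compounds with values here, no measured step resembles this change, and no step has a readable size, so the direction of a step that the limit leaves unreadable from compound 3 to compound 4 is only a guess; a small acetamido group is expected to bind more weakly than the aroyl amides. Compound 4 is estimated at 6000 nM, between 1000 nM and 30000 nM.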

Compound 4, inhibition constant: < 10000 nM
Compound 4 gave a limit, no number (the forecaster's own chance of this, stated with the estimate: 60%); the middle value does not contradict the limit.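

No step from compound 1, compound 2 or compound 3 to compound 4 can be read, since every value is only a limit: the limit of < 10000 nM in this assay, at which 4 of the 4 values shown sit.

Going by these compounds, how strongly each of these four compounds binds stays open, and so does whether the group on the carbonyl carbon changes binding at all.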